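Methyl to Ethyl on an Inactive Chloropyridine Analogue

This account rests on a few compounds, and the source may have more. Where it says the series, first, only, none or still open, it means among the compounds named here.

The series is read in a functional assay on cells for agonist activity at D(4) dopamine receptor (Homo sapiens), read by TR-FRET and cAMP accumulation, with a stated time of 30 min; a higher number here means that more compound is needed for the effect, a lower number that less compound is needed. Compound 1 `CCc1cccc(NC(=O)CN2CCN(c3ccccn3)CC2)c1` gives 28.7 nM. Compound 2 `Cc1cccc(NC(=O)CCN2CCN(c3ccccn3)CC2)c1`, which carries a longer chain between the amide and the piperazine, gives 612 nM. On these data alone, compound 3 `Cc1cccc(NC(=O)CN2CCN(c3ccc(Cl)cn3)CC2)c1`, in which a chlorine sits on the pyridine and the aniline bears a methyl, is reported as "not active" (no number reported), so no number stands for it in this assay and its place on the scale is unknown.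

Compound 4 `CCc1cccc(NC(=O)CN2CCN(c3ccc(Cl)cn3)CC2)c1` differs from compound 3 only at the aniline substituent: methyl in place of hydrogen on a saturated chain carbon bound to an aromatic carbon, that is methyl to ethyl, 3-methylphenyl to 3-ethylphenyl. Going by the values given here, no measured pair in this set isolates this change, so its size cannot be read from the data. Compound 1 shows that the 3-ethylphenyl group is compatible with potent activity on the unchlorinated core, while compound 3 shows the chlorinated core without a reported number. The expectation for compound 4 is therefore a weak or absent response, with a real chance that only a limit is reported. Compound 4 is estimated at 3000 nM, within a range of 400 nM to 20000 nM.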

Compound 4, half-maximal effective concentration: "not active" (no number reported)
The entry for compound 4 holds no number; there is nothing to compare the estimate with.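

Compound 3 and compound 4 both stand without a number in this assay, so no step can be read between them. Left open is how far compound 4, with its chlorine on the pyridine, stands from compound 1. No measured evidence bears on this result.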